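Swapping Fluoro for Chloro at the Far Phenyl Ring

The source may hold more compounds than are shown below. What is called first, only, known or untested is meant among the compounds shown, and "the series" means these compounds.

Measured compounds:
- compound 1 `Cc1ccc(-c2nc(C)c(COc3ccc(OCC(=O)O)c(F)c3)s2)cc1`: 156 nM
- compound 2 `Cc1nc(-c2ccccc2)sc1COc1ccc2c(c1)OCC2CC(=O)O`: 102 nM
- compound 3 `Cc1nc(-c2ccc(F)cc2)sc1COc1ccc2c(c1)OCC2CC(=O)O`: 79 nM

All three were tested in an assay on CHO cells for agonist activity at Free fatty acid receptor 1 (Homo sapiens), read by FLIPR; on this read-out higher numbers stand for an effect only at larger amounts of compound and lower numbers for an effect already at smaller amounts. Compound 3 has the lowest of the three numbers, but its distance to compound 2 is small, a 1.3-fold lower number from compound 2 to compound 3 (0.11 log units; within the scatter), and even compound 1 sits only within the usual scatter of it, so none of the three can be called stronger or weaker than the others on these data.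

Compound 4 `Cc1nc(-c2ccc(Cl)cc2)sc1COc1ccc2c(c1)OCC2CC(=O)O` keeps the whole framework of compound 3 and changes one atom: chloro in place of fluoro on an aromatic carbon. Within the data shown here, no measured pair covers this exchange. Among the measured compounds shown here, the only neighbouring step is the one from hydrogen to fluoro at the same carbon, which gave a 1.3-fold lower number from compound 2 to compound 3 (0.11 log units; within the scatter), a change too small to separate from repeat-to-repeat variation. With nothing pointing clearly in either direction, the expectation for this assay is a step of no more than the scatter, put here as a 1.3-fold lower number from compound 3 to compound 4 (0.12 log units; within the scatter). Compound 4 is therefore estimated at 60 nM, with a plausible range from 25 nM to 150 nM.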

Compound 4, half-maximal effective concentration: 105 nM
The estimate for compound 4 lay 1.8-fold (0.24 log units) below the measured number; low and high end bracket the measured number.
By their numbers in this assay, from the lowest: compounds 3, 2, 4 and 1 (each within the scatter of the next).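

Read together, the two new steps extend what was seen at this aromatic carbon. Going from 4-fluorophenyl to 4-chlorophenyl gives a 1.3-fold higher number from compound 3 to compound 4 (0.12 log units; within the scatter) and putting chloro in place of hydrogen gives a 1.0-fold higher number from compound 2 to compound 4 (0.01 log units; within the scatter), so in this assay hydrogen, fluoro and chloro at this carbon all lie within the scatter of one another, whereas the earlier pair covered only hydrogen and fluoro. The read-out therefore does not separate these three substituents at this place, and no further measurement is available that could explain why they sit so close together.

The compounds shown compare only hydrogen and these two halogens here, so it remains open whether a methoxy group, a trifluoromethyl group, a nitrile or an amine on the same carbon would also stay within the scatter or would move the number clearly in one direction. From the compounds shown here alone, it also remains open whether fluoro and chloro would read as closely alike on other carbons of this phenyl ring.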